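A few compounds are considered here, and "the series" means these few. Any claim that something is new, unique, unknown or untested is made for them only; others in the source may bear on it.

Measured so far:
- compound 1, `Cc1ccc(C2=NN(C(N)=S)C(c3ccc(Cl)cc3)C2)cc1`: 31 nM
- compound 2, `Cc1ccc(C2=NN(C(N)=S)[C@@H](c3ccc(Cl)cc3)C2)cc1`: 13 nM

In an assay on mitochondria for inhibition of Amine oxidase [flavin-containing] A (Bos taurus) (a higher number here means a weaker inhibitor, a lower number a stronger inhibitor), compound 1 gives 31 nM, and in this assay compound 2 gives 13 nM. Among the compounds with values here, compound 2 holds the lowest number of the two; the only measured step is a 2.4-fold lower number from compound 1 to compound 2 (0.38 log units; beyond the scatter), and that step is plausibly tied to the fact that one of compounds 1 and 2 is drawn with a defined configuration and the other without, at the place where they differ, since compound 1 is drawn without a configuration at the saturated ring carbon and compound 2 with one.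

Compound 3, `Cc1ccc(C2=NN(C(N)=S)[C@H](c3ccc(Cl)cc3)C2)cc1`, is not yet measured. It differs from compound 2 as follows: the two compounds have the same atoms and bonds and differ only in configuration as drawn: 1 of 1 stereo elements differ; a stereocentre at a saturated ring carbon is drawn R in compound 2 and S in compound 3. The step from the undefined compound 1 to the R-drawn compound 2 is the one that bears on this. With a 2.4-fold lower number from compound 1 to compound 2 (0.38 log units; beyond the scatter) already making compound 2 the lower number, the S-drawn compound 3 is expected to move the other way, towards a higher number than compound 2, likely also somewhat above compound 1. The expected step is a 6.2-fold higher number from compound 2 to compound 3 (0.79 log units; beyond the scatter), and compound 3 is estimated at 80 nM, within a range of 25 nM to 300 nM.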

Compound 3, inhibition constant: 50 nM
Compound 3: middle estimate off by 1.6-fold (0.20 log units), on the high side; the measured number falls inside the stated range.
By their numbers in this assay, from the lowest: compound 2; then compounds 1 and 3 (each within the scatter of the next).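

The configuration at the saturated ring carbon matters in this assay, though only modestly, with a 3.8-fold higher number from compound 2 to compound 3 (0.59 log units; beyond the scatter) and the R-drawn form giving the lower number of the defined pair, a gap that can be read on stereochemistry alone: the fact that compounds 2 and 3 differ only in the configuration as drawn. Within the data shown here, the S-drawn form does not separate from the material drawn without a configuration, with a 1.6-fold higher number from compound 1 to compound 3 (0.21 log units; within the scatter), so the earlier step to compound 2 is now the only one from compound 1 that lies beyond the scatter, and compounds 1 and 3 cannot be ranked against each other. Inversion at this carbon does not abolish binding, since compound 3 still gives 50 nM, so this position tolerates either drawn configuration, with a modest preference for R in this pair.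

Going by these compounds, the stereoisomer composition of compound 1 is unknown, so its value cannot be interpreted as a mixture of compounds 2 and 3. On these data alone, it also remains open whether the preference for the R-drawn form persists when the chlorine on the aryl group is replaced by a methoxy group or an amine, or when the thiocarbonyl is replaced by a carbonyl.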